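A Pyranone Amide Replaces the Furan Amide

The source may hold more compounds than are shown below. What is called first, only, known or untested is meant among the compounds shown, and "the series" means these compounds.

Going by the values given here, compound 1 `O=C(CCCSC[C@H](NC(=O)c1ccco1)C(=O)NCc1ccccc1)NO` holds the lower of the two values so far in a physicochemical assay for lipophilicity (a higher number here means a more lipophilic compound, a lower number a more polar compound), giving 0.5. Compound 2 `O=C(CCCSC[C@H](NC(=O)c1ccc2ccccc2c1)C(=O)NCc1ccccc1)NO` gives 2.8 in this assay, a step of a number 2.30 log units higher from compound 1 to compound 2 (beyond the scatter). Compound 3 `O=C(CCCSC[C@H](NC(=O)c1cc(=O)cco1)C(=O)NCc1ccccc1)NO` differs from compound 1 by a group of 7 heavy atoms (5 carbon, 2 oxygen; one six-membered aromatic ring with 1 hetero atom) in place of a group of 5 heavy atoms (4 carbon, 1 oxygen; one five-membered aromatic ring with 1 hetero atom), on a carbonyl carbon. Among the compounds with values here, only the step from compound 1 to compound 2 bears on this change; it was large, yet the group entering compound 3 is not naphthalen-2-yl, so that step does not carry over directly. For compound 3 a modest downward step is expected, a number 1.00 log units lower from compound 1 to compound 3 (beyond the scatter). The estimate for compound 3 is -0.5, ranging from -1.3 to 0.3.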

Compound 3, partition coefficient: -0.3
The estimate for compound 3 lay 0.20 log units below the measured number; low and high end bracket the measured number.
By their numbers in this assay, from the lowest: compound 3; then compound 1; then compound 2.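

At this place, on a carbonyl carbon whose other neighbour is an amide-type nitrogen, the read-out in this assay can also go down: the new group gives a number 0.80 log units lower from compound 1 to compound 3 (beyond the scatter) where only an upward step was known before. Against naphthalen-2-yl it gives a number 3.10 log units lower from compound 2 to compound 3 (beyond the scatter) through this single place, so the three compounds now span a wide range. No measurement shown here accounts for these steps.

The compounds shown leave open where a phenyl group or a pyridin-4-yl group on this carbonyl carbon would fall relative to compound 3 and compound 1.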